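Aryl swap on compound 2: expected cytotoxicity of compound 4

A few compounds are considered here, and "the series" means these few. Any claim that something is new, unique, unknown or untested is made for them only; others in the source may bear on it.

Compound 1 `CC(C)=CCC/C(C)=C/CC/C(C)=C/CC[C@@H]1[C@@]2(C)CCC(=O)C(C)(C)[C@@H]2CC[C@@]1(C)O` is the parent without any aryl group; in a functional assay on DU-145 cells (Homo sapiens) for cytotoxicity, read by MTT assay, with a stated time of 48 h (on this read-out lower numbers stand for stronger inhibition and higher numbers for weaker inhibition), compound 1 gives 13200 nM. Compound 2 `CC(C)=CCC/C(C)=C/CC/C(C)=C/CC[C@@H]1[C@@]2(C)CC/C(=N\OCc3cn(-c4ccc(Cl)cc4)nn3)C(C)(C)[C@@H]2CC[C@@]1(C)O` gives 16200 nM in this assay, and compound 3 `CC(C)=CCC/C(C)=C/CC/C(C)=C/CC[C@@H]1[C@@]2(C)CC/C(=N\OCc3cn(-c4cccc(Br)c4)nn3)C(C)(C)[C@@H]2CC[C@@]1(C)O` gives 14600 nM. Among the measured compounds shown here, on these numbers compound 2 lies within the scatter of both compound 3 and compound 1, and the one single-point step, a 1.1-fold lower number from compound 2 to compound 3 (0.05 log units; within the scatter), is flat. Compound 4 `CC(C)=CCC/C(C)=C/CC/C(C)=C/CC[C@@H]1[C@@]2(C)CC/C(=N\OCc3cn(-c4cccc([N+](=O)[O-])c4)nn3)C(C)(C)[C@@H]2CC[C@@]1(C)O` differs from compound 2 by 3-nitrophenyl in place of 4-chlorophenyl on an aromatic nitrogen. For the measured compounds named here, the only precedent bearing on this is that aryl exchange, which moved nothing beyond the scatter, and compound 1 sits in the same band; no step beyond the scatter is therefore expected in this assay. Compound 4 is expected near 15000 nM, range 7000 nM to 32000 nM, that is a 1.1-fold lower number from compound 2 to compound 4 (0.03 log units; within the scatter).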

Compound 4, half-maximal inhibitory concentration: 17400 nM
Estimate against measurement, compound 4: 1.2-fold (0.06 log units) below; measured number inside the range.
By their numbers in this assay, from the lowest: compounds 1, 3, 2 and 4 (each within the scatter of the next).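

In this assay, the change on the aromatic nitrogen gives a 1.1-fold higher number from compound 2 to compound 4 (0.03 log units; within the scatter), and nitro in place of bromo on an aromatic carbon gives a flat result as well (a 1.2-fold higher number from compound 3 to compound 4 (0.08 log units; within the scatter)). This position has now taken a nitro-bearing aryl group as well as the two halogen-bearing ones, with no step beyond the scatter among compounds 2, 3 and 4. No evidence is available that would explain this flatness. Still open, from the compounds shown here alone, is whether an aminophenyl or carboxyphenyl group, or a longer alkyl chain in place of the aryl group, would move the number at this position.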